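The source may report more compounds than this note shows. Statements on the series, on what has been measured and on what is new or still open speak of the compounds shown alone.

Measured compounds:
Compound 1 `CC1=NN(C(=O)CCc2ccccc2)C(c2cc(Br)cc(Br)c2O)C1` gives 11300 nM
Compound 2 `CC1=NN(C(=O)CN2CCN(C)CC2)C(c2ccccc2O)C1` gives 11800 nM
Compound 3 `O=C(c1ccccc1)N1N=C(c2cc3ccccc3oc2=O)CC1c1ccccc1` gives 5870 nM

These three were tested in a functional assay on PC-3 cells (Homo sapiens) for cytotoxicity, read by MTT assay, with a stated time of 48 h; a lower number here means a stronger inhibitor, a higher number a weaker inhibitor. Compound 3 has the lowest of the three numbers, but its distance to compound 1 and to compound 2 falls within the usual scatter of such measurements, so no order among the three can be claimed. Compound 4 `O=C(CN1CCCC1)N1N=C(c2cc3ccccc3oc2=O)CC1c1ccccc1` has not yet been measured in this assay. It differs from compound 3 at one place: (pyrrolidin-1-yl)methyl in place of phenyl on a carbonyl carbon. For the measured compounds named here, nothing among the measured compounds shows this same change on the shared core, so there is no measured step to lean on. Compound 2, which carries an aminomethyl group on its carbonyl carbon, gives a number close to that of compound 1, but its core differs from that of compound 3, so this says little about compound 4. With no guide, the expected step is small, estimated as a 1.2-fold higher number from compound 3 to compound 4 (0.08 log units; within the scatter), with no clear direction beyond the scatter. Compound 4 is therefore estimated at 7000 nM, within a range from 2500 nM to 20000 nM.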

Compound 4, half-maximal inhibitory concentration: 50200 nM
Compound 4: the middle estimate sits 7.2-fold (0.86 log units) below what was measured; the whole stated range lies below it.
By their numbers in this assay, from the lowest: compounds 3, 1 and 2 (each within the scatter of the next); then compound 4.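

In this assay, the group on this carbonyl carbon clearly matters: on the shared core, (pyrrolidin-1-yl)methyl in place of phenyl gives an 8.6-fold higher number from compound 3 to compound 4 (0.93 log units; beyond the scatter), a weaker result even though both groups have the same count of heavy atoms. The earlier compounds shown here could not show this, as they differ from one another in more than one place and their numbers all lie within the scatter of each other. No measurement at hand bears on the reason for this weakening.

Still open, as far as these compounds go, is whether the weakening goes with losing the aromatic ring or with gaining the nitrogen: a benzyl group would keep an aromatic ring on a methyl, while a cyclopentylmethyl group would keep a non-aromatic ring without nitrogen. From the compounds shown here alone, whether the same change has a similar effect on other cores also remains open.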